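The source may report more compounds than this note shows. Statements on the series, on what has been measured and on what is new or still open speak of the compounds shown alone.

Compound 1 `CSc1nc(NCCCCc2ccccc2)c2ccccc2n1` — > 100000 nM
Compound 2 `CSc1nc(NCCCCCO)c2ccccc2n1` — > 100000 nM

Of the compounds shown here, two sharing one core have been tested in a functional assay on CCRF-CEM cells (Homo sapiens) for cytotoxicity, read by MTT assay, with a stated time of 72 h; on this read-out higher numbers stand for weaker inhibition of growth and lower numbers for stronger inhibition of growth. Compound 1 gives only a limit of the assay, > 100000 nM. Compound 2 gives only a limit as well, > 100000 nM. The step that the two limits leave unreadable from compound 1 to compound 2 therefore has no readable size, since both values sit at the limit of > 100000 nM in this assay, at which 2 of the 2 values shown sit.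

Compound 3 `CSc1nc(Nc2ccccc2)c2ccccc2n1` has not yet been measured. It differs from compound 2 by phenyl in place of 5-hydroxypentyl on a nitrogen on an aromatic ring. Among the compounds with values here, no measured step touches this exchange: the only step recorded concerns the far end of the chain and is itself unreadable. Compound 2 stands at the limit, and nothing measured points to a change in either direction. Compound 3 is therefore expected to remain near that limit, estimated at 100000 nM with a range from 30000 nM to 300000 nM. The step from compound 2 to compound 3 is expected to be a number no higher from compound 2 to compound 3 (the limit leaves the size open), nothing beyond the scatter.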

Compound 3, concentration for total growth inhibition: > 100000 nM
Compound 3 gave a limit, no number; the forecaster's own chance of this, stated with the estimate: 75%; the middle value sits exactly at the limit.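

Compound 3 gives > 100000 nM, which is a limit and not a number. No step can be read between compound 2 and compound 3, because both stand at that limit: the limit of > 100000 nM in this assay, at which 3 of the 3 values shown sit.

The compounds shown leave open whether their groups on the shared core differ at all in growth inhibition.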